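From Methoxy to Hydroxy in a Weakly Active Pair

The source may report more compounds than this note shows. Statements on the series, on what has been measured and on what is new or still open speak of the compounds shown alone.

Within the data shown here, compound 1 `O=C(N/N=C/c1ccccc1O)c1ccc(-c2ccc(F)cc2)o1` and compound 2 `COc1ccccc1/C=N/NC(=O)c1ccc(-c2ccc(F)cc2F)o1` share one core but differ in two places, so no single step connects them. In a functional assay on HL-60 cells (Homo sapiens) for antiproliferative activity, read by MTT assay, with a stated time of 48 h (on this read-out higher numbers stand for weaker inhibition and lower numbers for stronger inhibition), compound 1 gives 63100 nM. For compound 2 the read-out in this assay stops at a limit of the assay, > 40000 nM, so only a range is known; it sits at the limit of > 40000 nM in this assay, at which 1 of the 2 values shown sits. Both results describe weak inhibition. Compound 3 `O=C(N/N=C/c1ccccc1O)c1ccc(-c2ccc(F)cc2F)o1` is compound 2 with hydrogen in place of methyl on an oxygen on an aromatic ring. Among the measured compounds shown here, no measured pair isolates this change, so its effect is unknown; the only guidance is that compound 1, which also carries a hydroxy group, gives 63100 nM. Compound 3 is expected to remain weak, with a step estimated as a step that the limit leaves unreadable from compound 2 to compound 3, likely within the scatter. In this assay compound 3 is estimated at 50000 nM, between 20000 nM and 150000 nM.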

Compound 3, half-maximal inhibitory concentration: 16400 nM
For compound 3 the middle estimate is 3.0-fold (0.48 log units) above the measured one; measured number below the stated range.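

In this assay, the change from 2-methoxyphenyl to 2-hydroxyphenyl gives an at least 2.4-fold lower number from compound 2 to compound 3 (0.38 log units; beyond the scatter), so the group on this oxygen does affect the read-out. For compound 2 the assay gives only a limit, so the full size of this step cannot be read: the limit of > 40000 nM in this assay, at which 1 of the 3 values shown sits. With the hydroxy group kept in place, fluoro in place of hydrogen on an aromatic carbon gives a 3.8-fold lower number from compound 1 to compound 3 (0.59 log units; beyond the scatter), which shows that a change elsewhere on the molecule also moves the number.

From the compounds shown here alone, how an ethyl group on this oxygen, or an amine in place of the hydroxy group, would read remains open. Also open, going by these compounds, is whether the change from methoxy to hydroxy would have a similar effect on the core of compound 1.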